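The source may report more compounds than this note shows. Statements on the series, on what has been measured and on what is new or still open speak of the compounds shown alone.

Measured compounds:
compound 1 `CC(C)(C)Cc1nn(CCC2CC2)c(=O)c(C2=NS(=O)(=O)c3cc(NS(C)(=O)=O)ccc3N2)c1O`: > 100000 nM
compound 2 `CC(C)CCn1nc(CC(C)(C)C)c(O)c(C2=NS(=O)(=O)c3cc(NS(C)(=O)=O)ccc3N2)c1=O`: > 100000 nM

In a physicochemical assay for solubility, at pH 7.4 (a lower number here means a less soluble compound, a higher number a more soluble compound), compound 1 gives > 100000 nM, which is a limit of the assay and not a number. In this assay compound 2 likewise gives > 100000 nM, again a limit. Among the compounds with values here, compound 2 therefore stands at the top of what the assay reports, together with the only other value shown: the limit of > 100000 nM in this assay, at which 2 of the 2 values shown sit. Within the data shown here, the single measured step, a step that the two limits leave unreadable from compound 1 to compound 2, is one that the two limits leave unreadable, so its size is not known.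

Compound 3 `CC(C)(C)CCn1nc(CC(C)(C)C)c(O)c(C2=NS(=O)(=O)c3cc(NS(C)(=O)=O)ccc3N2)c1=O` differs from compound 2 by methyl in place of hydrogen on a saturated chain carbon bound to three saturated chain carbons. Among the measured compounds shown here, no measured step of the same kind exists, and the one step between the two measured compounds has no readable size, so it gives no basis for a direction; the expectation is simply that compound 3 behaves as compound 2 does at this limit. Compound 3 is thus expected to give about 150000 nM in this assay, within a range of 50000 nM to 500000 nM, most likely reported again as a limit. The step expected is a step that the limit leaves unreadable from compound 2 to compound 3, none beyond the scatter.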

Compound 3, solubility: > 100000 nM
Compound 3 was reported as a limit; the forecaster's own chance of this, stated with the estimate: 80%; the middle value lies beyond the limit too.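

In this assay compound 3 gives > 100000 nM, which is a limit of the assay and not a number. No step among compound 1, compound 2 and compound 3 can be read, as all of them stand at the same limit: the limit of > 100000 nM in this assay, at which 3 of the 3 values shown sit.

The compounds shown leave open how far the solubility of these three compounds actually differs.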